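From 3-Methylpiperazin-1-yl to 4-Methylpiperazin-1-yl

The source may hold more compounds than are shown below. What is called first, only, known or untested is meant among the compounds shown, and "the series" means these compounds.

Measured compounds, with their values in a functional assay on SV5A8 cells (Homo sapiens) for cytotoxicity; a lower number here means a stronger inhibitor, a higher number a weaker inhibitor:
compound 1 `Cc1ccc2c(NCc3ccc(NC(=O)C4CCN(Cc5ccc(F)cc5)CC4)cc3)nc(N(C)C)nc2c1` — > 4820 nM, a limit
compound 2 `Cc1ccc2c(NCc3ccc(NC(=O)C4CCN(Cc5cccc(F)c5)CC4)cc3)nc(N(C)C)nc2c1` — > 4170 nM, a limit
compound 3 `Cc1ccc2c(NCc3ccc(NC(=O)C4CCN(Cc5ccccc5)CC4)cc3)nc(N3CCN[C@@H](C)C3)nc2c1` — > 8860 nM, a limit

In this assay compound 3 stands only at a limit, as do the two other compounds, and the line the limit of > 8860 nM in this assay, at which 1 of the 3 values shown sits, records that standing. Compound 4 `Cc1ccc2c(NCc3ccc(NC(=O)C4CCN(Cc5ccccc5)CC4)cc3)nc(N3CCN(C)CC3)nc2c1` has not been measured. It differs from compound 3 in one place: 4-methylpiperazin-1-yl in place of 3-methylpiperazin-1-yl on an aromatic carbon. Among the measured compounds shown here, the only step between measured compounds, a step that the two limits leave unreadable from compound 1 to compound 2, concerns a different part of the molecule, and its size is not readable because both compounds sit at limits the limit of > 4170 nM in this assay, at which 1 of the 3 values shown sits (the limit of > 4820 nM in this assay, at which 1 of the 3 values shown sits). For the measured compounds named here, no measured step therefore bears on the present change, and no direction can be read for it beyond the scatter. Compound 4 is expected to remain at a limit in this assay, with an estimated value of 12000 nM and a range of 3000 nM to 50000 nM. The step that the limit leaves unreadable from compound 3 to compound 4 that this estimate implies is expected to be indistinguishable from no change.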

Compound 4, half-maximal inhibitory concentration: > 17700 nM
Compound 4: no number, only a limit; the forecaster's own chance of this, stated with the estimate: 80%; at least 1.4-fold (0.16 log units) between middle value and limit.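

In this assay, compound 3 and compound 4 both stand only at limits, so the step between them cannot be read. The compounds shown leave open whether 4-methylpiperazin-1-yl in place of 3-methylpiperazin-1-yl changes the half-maximal inhibitory concentration at all, and in which direction.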